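Swapping a methyl for a fluoro on a tolerated sulfonamide

The source may report more compounds than this note shows. Statements on the series, on what has been measured and on what is new or still open speak of the compounds shown alone.

Of the compounds shown here, three from this series have been tested in an ADME assay on L02 cells (Homo sapiens) for cytotoxicity, read by MTT assay, with a stated time of 24 h; a lower number here means that less compound is tolerated, a higher number that more compound is tolerated. Compound 1 `Cc1ccccc1-n1cc(-c2ccccc2NS(=O)(=O)c2c[nH]c(=O)[nH]c2=O)nn1` gives 56600 nM. Compound 2 `O=c1[nH]cc(S(=O)(=O)Nc2ccccc2-c2cn(-c3cccc(F)c3)nn2)c(=O)[nH]1` is recorded only as "not toxic" (no number reported), without a single number. Compound 3 `Cc1ccccc1-n1cc(-c2ccc(NS(=O)(=O)c3c[nH]c(=O)[nH]c3=O)cc2)nn1` likewise stands without a single number, recorded as "not toxic" (no number reported), so its place on the numbers shown cannot be fixed more closely; it shares this with compound 2, and only compound 1 carries a numeric value here.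

The next compound, compound 4 `O=c1[nH]cc(S(=O)(=O)Nc2ccc(-c3cn(-c4ccccc4F)nn3)cc2)c(=O)[nH]1`, keeps the core of compound 3 and differs in one place: fluoro in place of methyl on an aromatic carbon. The change sits on an aromatic carbon of a six-membered aromatic ring of carbon only, ortho to a large group, and read one bond further out it is 2-methylphenyl to 2-fluorophenyl.

For the measured compounds named here, no measured pair in this set separates the effect of this change, so no step size can be read off. On the available data, compound 3 and compound 2 both appear tolerated without a number, while compound 1 is the only numeric point. For compound 4, the expectation is therefore no shift beyond the scatter in this assay, and most likely again no number reported. The estimated value for compound 4 is 90000 nM, with a range from 30000 nM to 300000 nM.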

Compound 4, half-maximal cytotoxic concentration: > 100000 nM
Compound 4 ended at the assay's limit; the forecaster's own chance of this, stated with the estimate: 70%; middle value at least 1.1-fold (0.04 log units) from the limit.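

No step can be read between compound 3 and compound 4, since compound 3 is recorded only as "not toxic", without a number. In this assay compound 4 gives > 100000 nM, which is a limit of the assay and not a number. The compounds shown leave open how much the change from 2-methylphenyl to 2-fluorophenyl alters the concentration tolerated.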